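Fluoro for chloro: compound 1 to compound 4

A few compounds are considered here, and "the series" means these few. Any claim that something is new, unique, unknown or untested is made for them only; others in the source may bear on it.

The series is read in a functional assay on THP-1 cells (Homo sapiens) for inhibition, read by ELISA, with stated times of 30 min and 24 h, tested at 10 uM; a lower number here means a weaker effect, a higher number a stronger effect of the compound at the concentration tested. Compound 1 `COc1cc(OC)c(C(=O)c2cccc(Cl)c2)c(O)c1CN1CCCC1` gives 81%, the lowest of the three numbers recorded. Compound 2 `COc1cc(OC)c(C(=O)c2cccc(Cl)c2)c(O)c1CN1CCCCC1` gives 83%, and the step of a number 2 percentage points higher from compound 1 to compound 2 (within the scatter) stays within the scatter. Compound 3 `COc1cc(OC)c(C(=O)c2ccccc2Br)c(O)c1CN1CCCCC1` gives 98%, reached by the step of a number 15 percentage points higher from compound 2 to compound 3 (beyond the scatter). Compound 1 and compound 3 have not been compared as a single step; their two values differ beyond the scatter.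

Compound 4 `COc1cc(OC)c(C(=O)c2cccc(F)c2)c(O)c1CN1CCCC1` is not yet measured. It differs from compound 1 by fluoro in place of chloro on an aromatic carbon. For the measured compounds named here, no measured step exchanges one halogen for another at the same place on the 3-chlorophenyl group. The step of a number 15 percentage points higher from compound 2 to compound 3 (beyond the scatter) alters the halogen and its position at once and is only modest; the step of a number 2 percentage points higher from compound 1 to compound 2 (within the scatter) touches a different part of the core of compound 1 and stays within the scatter. Neither gives a direct guide, so for compound 4 no step beyond the scatter is expected in this assay, and no direction can be called with confidence. The expected step is a number 3 percentage points lower from compound 1 to compound 4 (within the scatter). Compound 4 is therefore estimated at 78%, within a range of 60% to 92%.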

Compound 4, a percentage reported as activity, at one concentration (the size of the read-out at that concentration, not a potency): 93%
Beside the measured number, compound 4's estimate is 15 percentage points below it, outside the stated range (above it).
By their numbers in this assay, from the lowest: compounds 1, 2, 4 and 3 (each within the scatter of the next, the first and the last beyond it).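

In this assay, for the compounds shown here, the step of a number 12 percentage points higher from compound 1 to compound 4 (beyond the scatter) is the only one that exchanges one halogen for another while the place stays fixed, on an aromatic carbon meta to a large group. It shows that this exchange alone, with the pyrrolidin-1-yl group and the rest of the core of compound 1 unchanged, moves the number beyond the scatter, though only modestly. The earlier step of a number 15 percentage points higher from compound 2 to compound 3 (beyond the scatter) could not show this, since it changed the identity and the position of the halogen together, and nothing is available that accounts for the new step.

Going by these compounds, whether the 3-chlorophenyl to 3-fluorophenyl change gives a similar step alongside the piperidin-1-yl group of compound 2 remains open, so the step cannot yet be treated as independent of the amine. Also open, on these data alone, is how bromo, methoxy or a nitrile at this same place would read in this assay, and so whether the two halogen values belong to any wider trend.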